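Swapping a Fluorinated Tail for a Methoxy Tail

The compounds below may be only part of what the source reports. "The series", "measured", "known", "first", "only" and "open" are said of these compounds alone.

Three urea compounds with a shared core have been tested in a functional assay on HFL1 cells for antagonist activity at sphingosine 1-phosphate receptor 2 (Homo sapiens), read by ELISA, with a stated time of 24 h, in the presence of a further agent that is not named here; a higher number here means a weaker inhibitor, a lower number a stronger inhibitor. Compound 1 `Cc1cc(CNC(=O)Nc2cc(Cl)nc(OCC(F)F)c2)nnc1-c1cn(C)nc1C(F)(F)F` gives 71000 nM. Compound 2 `CCOc1cc(NC(=O)NCc2cc(C)c(-c3cn(C)nc3C(F)(F)F)nn2)cc(C#N)n1` gives 67000 nM, and compound 3 `CCOc1cc(NC(=O)NCc2cc(C)c(-c3cn(C)nc3C(F)(F)F)nn2)cc(C)n1` gives 194000 nM. Compound 1 thus stands second highest of the three; its number and that of compound 2 lie within the usual scatter, while the gap to compound 3 lies beyond it. Within the data shown here, the one measured step, a 2.9-fold higher number from compound 2 to compound 3 (0.46 log units; beyond the scatter), concerns a different part of the molecule and says nothing about the chain carbon changed here.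

Compound 4 `COCCOc1cc(NC(=O)NCc2cc(C)c(-c3cn(C)nc3C(F)(F)F)nn2)cc(Cl)n1` differs from compound 1 by methoxymethyl in place of difluoromethyl on a saturated chain carbon bound to an oxygen on an aromatic ring. Among the measured compounds shown here, no measured pair shows the effect of this change, so there is nothing to suggest a move beyond the scatter in this assay in either direction. Compound 4 is therefore expected to give 71000 nM, with a range from 25000 nM to 200000 nM. From the measured value of compound 1, the expected change is no change at the digits printed from compound 1 to compound 4 (within the scatter), within the scatter.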

Compound 4, half-maximal inhibitory concentration: 3220000 nM
Compound 4: middle estimate off by 45-fold (1.66 log units), on the low side; the measured number lies above the stated range.
By their numbers in this assay, from the lowest: compounds 2 and 1 (each within the scatter of the next); then compound 3; then compound 4.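

In this assay the chain on this oxygen turns out not to be a silent spot: changing 2,2-difluoroethoxy to 2-methoxyethoxy gives a 45-fold higher number from compound 1 to compound 4 (1.66 log units; beyond the scatter), so compound 4 is a much weaker inhibitor even though the leaving and entering groups match in heavy-atom count and differ in that methoxymethyl carries a hydrogen-bond acceptor. This step is far larger than the only earlier one, a 2.9-fold higher number from compound 2 to compound 3 (0.46 log units; beyond the scatter), which came from a change elsewhere on the molecule. Nothing available here explains why the swap costs so much.

On these data alone, what remains open is whether the entering oxygen, the departing fluorines or both drive the shift. A 2-hydroxyethoxy or 2-aminoethoxy chain on the same chloro-bearing compound, or a longer 3-methoxypropoxy chain, would test how this position responds.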